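Hydrazone series: cytotoxicity, chloro to bromo step

This account rests on a few compounds, and the source may have more. Where it says the series, first, only, none or still open, it means among the compounds named here.

Measured so far in an ADME assay on NIH3T3 cells (Mus musculus) for cytotoxicity, read by MTT assay, with a stated time of 24 h; a lower number here means a stronger inhibitor, a higher number a weaker inhibitor:
compound 1 `O=C(CSc1nnc(-c2ccncc2)o1)N/N=C/c1ccc(Br)cc1` gives 169000 nM
compound 2 `COc1ccc(/C=N/NC(=O)CSc2nnc(-c3ccncc3)o2)cc1` gives 132000 nM
compound 3 `O=C(CSc1nnc(-c2ccncc2)o1)N/N=C/c1cc(Cl)ccc1O` gives 166000 nM

Compound 3 stands second highest of the three numbers; none of the three values separates from another, as a 1.0-fold lower number from compound 1 to compound 3 (0.01 log units; within the scatter) and a 1.3-fold higher number from compound 2 to compound 3 (0.10 log units; within the scatter) show, and the remaining pair, a 1.3-fold lower number from compound 1 to compound 2 (0.11 log units; within the scatter), also stays inside the scatter. The series therefore reads as flat in this assay across the changes made so far at the aryl end of the hydrazone.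

Compound 4 `O=C(CSc1nnc(-c2ccncc2)o1)N/N=C/c1cc(Br)ccc1O` differs from compound 3 by bromo in place of chloro on an aromatic carbon. Within the data shown here, no measured step exchanges one halogen for another; the closest comparison is the swap of bromo for methoxy, a 1.3-fold lower number from compound 1 to compound 2 (0.11 log units; within the scatter), which gave nothing beyond the scatter, and the move from 4-bromophenyl to 5-chloro-2-hydroxyphenyl, a 1.0-fold lower number from compound 1 to compound 3 (0.01 log units; within the scatter), likewise. On that basis the expected step is none beyond the scatter, a 1.0-fold lower number from compound 3 to compound 4 (0.02 log units; within the scatter). For compound 4 the estimated value is 160000 nM, with an expected range from 90000 nM to 280000 nM.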

Compound 4, half-maximal inhibitory concentration: 156000 nM
Beside the measured number, compound 4's estimate is 1.0-fold (0.01 log units) above it, and the stated range covers the measured number.
By their numbers in this assay, from the lowest: compounds 2, 4, 3 and 1 (each within the scatter of the next).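

In this assay the direct halogen exchange, bromo in place of chloro para to a hydroxy group, gives a 1.1-fold lower number from compound 3 to compound 4 (0.03 log units; within the scatter), so the two halogens do not separate at this position. The 5-bromo-2-hydroxyphenyl end also stays level with the other aryl ends, with a 1.2-fold higher number from compound 2 to compound 4 (0.07 log units; within the scatter) against 4-methoxyphenyl and a 1.1-fold lower number from compound 1 to compound 4 (0.03 log units; within the scatter) against 4-bromophenyl, and the series remains flat across all four compounds. No supporting measurement bears on this result.

Open, as far as these compounds go, is whether an amine or a carboxylic acid in place of the halogen would give a step beyond the scatter in this assay. From the compounds shown here alone, the shared core is the same in all four compounds, so the effect of a longer chain within it also remains open.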